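Thiophene for Fluorophenyl: Solubility Outlook for Compound 4

A few compounds are considered here, and "the series" means these few. Any claim that something is new, unique, unknown or untested is made for them only; others in the source may bear on it.

Compound 1, `CCCOc1ccc(C[C@@H](Cc2ccccc2)C(=O)O)cc1CNC(=O)c1ccc(-c2cccc(F)c2)cc1`, gives in a physicochemical assay for solubility, read by HPLC, in phosphate buffer, measured as thermodynamic solubility, with a stated time of 48 h, at pH 7.2 (on this read-out lower numbers stand for lower solubility and higher numbers for higher solubility), a value at the assay limit of < 1 ug/mL.
Compound 2, `CCCOc1ccc(C[C@@H](Cc2ccccc2)C(=O)O)cc1CNC(=O)c1ccc(-c2ccncc2)cc1`, gives in this assay 34.1 ug/mL.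
Compound 3, `CCCOc1ccc(C[C@@H](Cc2ccccc2)C(=O)O)cc1CNC(=O)c1ccc(-c2ccccc2F)cc1`, gives in this assay a value at the assay limit of < 1 ug/mL.

Compound 3 therefore stands at the limit, as the shared limit of < 1 ug/mL in this assay, at which 2 of the 3 values shown sit, shows. The measured steps give an at least 34-fold higher number from compound 1 to compound 2 (1.53 log units; beyond the scatter) and an at least 34-fold lower number from compound 2 to compound 3 (1.53 log units; beyond the scatter), both large, while a step that the two limits leave unreadable from compound 1 to compound 3. Compound 4, `CCCOc1ccc(C[C@@H](Cc2ccccc2)C(=O)O)cc1CNC(=O)c1ccc(-c2cccs2)cc1`, differs from compound 3 by thiophen-2-yl in place of 2-fluorophenyl on an aromatic carbon. The only large movement seen involved the pyridin-4-yl group; both fluorophenyl compounds sit at the limit. Compound 4 is thus expected to stay close to that limit, with an expected step of an at least 1.5-fold higher number from compound 3 to compound 4 (0.17 log units; that floor lies within the scatter). The estimate for compound 4 is 1.5 ug/mL, between 0.3 ug/mL and 8 ug/mL.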

Compound 4, solubility: < 1 ug/mL
Compound 4 was reported as a limit; the forecaster's own chance of this, stated with the estimate: 50%; at least 1.5-fold (0.17 log units) between middle value and limit.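

Thiophen-2-yl, a ring with a hetero atom, does not carry the value of pyridin-4-yl at this position, para to a large group: the change gives an at least 34-fold lower number from compound 2 to compound 4 (1.53 log units; beyond the scatter). The steps from compound 1 and from compound 3 to compound 4 cannot be read, with limits at both ends. Compound 4 shows that the limit at this position is not confined to the fluorophenyl groups: the limit of < 1 ug/mL in this assay, at which 3 of the 4 values shown sit.

Going by these compounds, how compound 1, compound 3 and compound 4 rank under that limit stays open. So does whether pyridin-3-yl or an aminomethyl group would leave it.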